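A few compounds are considered here, and "the series" means these few. Any claim that something is new, unique, unknown or untested is made for them only; others in the source may bear on it.

Compound 1 `CCCCCC(=O)c1ccc(OCCCN2CCN(C(=O)C(C)C)CC2)cc1`: 29500 nM
Compound 2 `CCCCCC(=O)c1ccc(OCCCN2CCN(CCCC)CC2)cc1`: 7590 nM
Compound 3 `CCOC(=O)N1CCN(CCCOc2ccc(C(C)=O)cc2)CC1`: 39800 nM

In an assay on isolated protein for binding affinity to histamine H2 receptor (Homo sapiens) (on this read-out higher numbers stand for weaker inhibition and lower numbers for stronger inhibition), compound 3 gives the highest of the three numbers; compound 1 sits within the scatter of it, while compound 2 lies well below it. Among the compounds with values here, the one single-place step measured, a 3.9-fold lower number from compound 1 to compound 2 (0.59 log units; beyond the scatter), concerns the amine nitrogen in the ring and not the carbonyl carbon, so it does not bear on the move to compound 4 `CCOC(=O)N1CCN(CCCOc2ccc(C(=O)c3cccc(C)c3)cc2)CC1`. That move: 3-methylphenyl in place of methyl on a carbonyl carbon. Compounds 1 and 3 differ both at the carbonyl carbon and at the ring nitrogen, yet their values sit within the scatter, giving no sign that the group on the carbonyl carbon moves the number much. Compound 4 is therefore expected at 20000 nM (range 5000 nM to 80000 nM), a step of a 2.0-fold lower number from compound 3 to compound 4 (0.30 log units; within the scatter) expected to fall within or only just beyond the scatter.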

Compound 4, inhibition constant: 3720 nM
Estimate against measurement, compound 4: 5.4-fold (0.73 log units) above, outside the stated range (below it).
By their numbers in this assay, from the lowest: compound 4; then compound 2; then compounds 1 and 3 (each within the scatter of the next).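

With the rest of compound 3 unchanged, 3-methylphenyl in place of methyl on a carbonyl carbon gives an 11-fold lower number from compound 3 to compound 4 (1.03 log units; beyond the scatter) in this assay, so the group at this position can shift the number substantially. The change brings one six-membered aromatic ring of carbon only, and neither group carries hydrogen-bond donors or acceptors. No supporting measurement accounts for the size of the step.

Going by these compounds, it remains open whether unsubstituted phenyl or 4-methylphenyl would give a similar step. On these data alone, it is also open whether 3-methylphenyl would have the same effect with butyl on the ring nitrogen, as in compound 2.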